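A few compounds are considered here, and "the series" means these few. Any claim that something is new, unique, unknown or untested is made for them only; others in the source may bear on it.

Compound 2 `ClCc1ccccc1Cn1cnc2c(Cl)ncnc21` gives 6160 nM in a functional assay on U-251 cells (Homo sapiens) for cytotoxicity, read by sulforhodamine B assay, with a stated time of 48 h (a lower number here means a stronger inhibitor of growth, a higher number a weaker inhibitor of growth), the highest of the three numbers at hand. Compound 1 `ClCc1ccccc1Cn1cnc2c(Cl)nc(Cl)nc21` gives 1020 nM in this assay, and compound 3 `ClCc1cccc(Cn2cnc3nc(Cl)nc(Cl)c32)c1` gives 2690 nM. The change to compound 4 `Nc1nc(Cl)c2ncn(Cc3ccccc3CCl)c2n1` is amino in place of hydrogen on an aromatic carbon. Among the compounds with values here, no measured step introduces an amino group. Within the data shown here, the one measured step, a 6.0-fold higher number from compound 1 to compound 2 (0.78 log units; beyond the scatter), concerns a chloro leaving the same aromatic carbon that the amino group now enters, and it is modest in size. Compound 4 thus puts a heavy atom back where compound 2 carries only hydrogen, so a step back down is expected, though not necessarily as large as the chloro step. The estimate for compound 4 is 2500 nM, in the range 800 nM to 8000 nM. That estimate means a step of a 2.5-fold lower number from compound 2 to compound 4 (0.39 log units; beyond the scatter) is expected.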

Compound 4, concentration for total growth inhibition: 13500 nM
The estimate for compound 4 lay 5.4-fold (0.73 log units) below the measured number; measured number above the stated range.
By their numbers in this assay, from the lowest: compound 1; then compound 3; then compound 2; then compound 4.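

In this assay, amino on this aromatic carbon between two ring nitrogen atoms gives a 2.2-fold higher number from compound 2 to compound 4 (0.34 log units; beyond the scatter) and, measured against chloro, a 13-fold higher number from compound 1 to compound 4 (1.12 log units; beyond the scatter). At this position, then, a heavy atom in itself does not lower the number: of the three groups compared, chloro gives the lowest number, then hydrogen, then amino. Nothing at hand accounts for this order.

Going by these compounds, whether fluoro, bromo or methoxy on this carbon would give a number nearer that of chloro or that of amino remains open. So does whether amino would have the same effect with the chloromethyl group placed as in compound 3.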